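The source may report more compounds than this note shows. Statements on the series, on what has been measured and on what is new or still open speak of the compounds shown alone.

Three thiosemicarbazide-type compounds have been measured in an in vitro assay on cells for inhibition of Amine oxidase [flavin-containing] B (Homo sapiens), read by Amplex Red, with a stated time of 15 min, tested at 100 uM; on this read-out higher numbers stand for more inhibition at the one concentration tested (going by the name of the read-out) and lower numbers for less inhibition. Compound 1 `CC1CN(C(N)=S)N=C1c1ccc(F)cc1` gives 40% in this assay. Compound 2 `Cc1ccc(C2=NN(C(N)=S)CC2C)cc1` gives 40%, and the step of no change at the digits printed from compound 1 to compound 2 (within the scatter) shows this aromatic swap makes no difference. Compound 3 `CNC(=S)N1CC(C)C(c2ccccc2)=N1` gives 40%, level with compounds 1 and 2 within the scatter.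

Compound 4 `CC1CN(C(N)=S)N=C1c1ccccc1` is yet to be measured in this assay. It differs from compound 3 by hydrogen in place of methyl on an amide-type nitrogen. Going by the values given here, no measured step touches this nitrogen, so the only guide is that all three measured compounds, across a change of aromatic substituent, sit at the same level. Compound 4 is therefore expected to stay level with compound 3, the expected step being no change at the digits printed from compound 3 to compound 4 (within the scatter). The estimate for compound 4 in this assay is 40%, with a range from 25% to 55%.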

Compound 4, a percentage reported as inhibition, at one concentration (the size of the read-out at that concentration, not a potency): 40%
Estimate against measurement, compound 4: no gap at the digits printed, within the range that was stated.
By their numbers in this assay, from the lowest: compounds 1, 2, 3 and 4 (each within the scatter of the next).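

Going from methylamino to amino on the amide-type nitrogen gives no change at the digits printed from compound 3 to compound 4 (within the scatter) in this assay, so this nitrogen carries either hydrogen or methyl at the same level. On the aromatic carbon, hydrogen matches both earlier substituents, with no change at the digits printed from compound 2 to compound 4 (within the scatter) for methyl and no change at the digits printed from compound 1 to compound 4 (within the scatter) for fluoro . No supporting data bear on this result.

On these data alone, what a longer chain on the amide-type nitrogen or an amine or carboxylic acid on the aromatic carbon would give remains open. Whether these four compounds also stay level at other concentrations is open too.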